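A Thioether Chain Replaces the Methoxypropoxy Group

The compounds below may be only part of what the source reports. "The series", "measured", "known", "first", "only" and "open" are said of these compounds alone.

Compound 1 `CCC1CCN(c2nc(C(C)(C)C)ccc2CNC(=O)C(C)c2ccc(NS(C)(=O)=O)c(F)c2)CC1` gives 0.1 nM in an assay on cells for antagonist activity at transient receptor potential cation channel subfamily V member 1 (Homo sapiens), read by FLIPR and calcium flux, with a stated time of 6 min; on this read-out lower numbers stand for stronger inhibition and higher numbers for weaker inhibition.
Compound 2 `CCOc1nc(C(C)(C)C)ccc1CNC(=O)C(C)c1ccc(NS(C)(=O)=O)c(F)c1` gives 14.8 nM in this assay.
Compound 3 `COCCCOc1nc(C(C)(C)C)ccc1CNC(=O)C(C)c1ccc(NS(C)(=O)=O)c(F)c1` gives 5.6 nM in this assay.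

Compound 3 stands second highest of the three numbers: the step of a 2.6-fold lower number from compound 2 to compound 3 (0.42 log units; beyond the scatter) is modest, whereas a 56-fold higher number from compound 1 to compound 3 (1.75 log units; beyond the scatter) is large, as is a 150-fold higher number from compound 1 to compound 2 (2.17 log units; beyond the scatter). The unmeasured compound 4 `CC(C(=O)NCc1ccc(C(C)(C)C)nc1SCCCN(C)C)c1ccc(NS(C)(=O)=O)c(F)c1` carries (3-(dimethylamino)propyl)sulfanyl in place of 3-methoxypropoxy on an aromatic carbon. Within the data shown here, no measured step exchanges an oxygen-linked chain for a sulfur-linked one, and none introduces a dimethylamino end; the only chain change among the measured compounds, a 2.6-fold lower number from compound 2 to compound 3 (0.42 log units; beyond the scatter), was modest. The large steps involve the 4-ethylpiperidin-1-yl group, which compound 4 does not carry. A step of modest size at most is therefore expected in this assay, its direction uncertain, so that a 1.1-fold lower number from compound 3 to compound 4 (0.05 log units; within the scatter) is the estimate. Compound 4 is expected to give 5 nM, between 1 nM and 25 nM.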

Compound 4, inhibition constant: 51.8 nM
Compound 4: the middle estimate sits 10-fold (1.02 log units) below what was measured, and the stated range ends below it.
By their numbers in this assay, from the lowest: compound 1; then compound 3; then compound 2; then compound 4.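

At this position in this assay, a sulfur-linked chain ending in dimethylamino does not keep the gain that 3-methoxypropoxy showed over ethoxy: a 9.3-fold higher number from compound 3 to compound 4 (0.97 log units; beyond the scatter) reverses that gain, and a 3.5-fold higher number from compound 2 to compound 4 (0.54 log units; beyond the scatter) places the new chain behind plain ethoxy. Among these compounds, the distance to the 4-ethylpiperidin-1-yl group also widens, with a 520-fold higher number from compound 1 to compound 4 (2.71 log units; beyond the scatter) being the largest step at this position so far. Nothing measured here accounts for the loss. Going by these compounds, the sulfur link and the dimethylamino end changed together, and which of them carries the loss stays open. A 3-(dimethylamino)propoxy chain or a (3-methoxypropyl)sulfanyl chain would separate them.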